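Amide nitrogen substituent variation in the shared core series

This account rests on a few compounds, and the source may have more. Where it says the series, first, only, none or still open, it means among the compounds named here.

Compound 1 `COc1ccc2c(=O)c(/C=C/C(=O)Nc3cccc(C)c3)coc2c1`: > 100000 nM
Compound 2 `COc1ccc2c(=O)c(/C=C/C(=O)Nc3ccccc3Cl)coc2c1`: 22400 nM
Compound 3 `COc1ccc2c(=O)c(/C=C/C(=O)NCc3ccc(F)cc3)coc2c1`: > 100000 nM

In a functional assay on HeLa cells (Homo sapiens) for inhibition, read by MTT assay, with a stated time of 48 h (on this read-out lower numbers stand for stronger inhibition and higher numbers for weaker inhibition), compound 3 gives only a limit of the assay, > 100000 nM. Two of the three readings sit at the limit of > 100000 nM in this assay, at which 2 of the 3 values shown sit. Compound 2 gives a number, 22400 nM.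

Compound 4 `COc1ccc2c(=O)c(/C=C/C(=O)Nc3ccc(Cl)cc3)coc2c1` differs from compound 3 by 4-chlorophenyl in place of 4-fluorobenzyl on an amide-type nitrogen. For the measured compounds named here, two measured steps bear on this. The step of an at least 4.4-fold higher number from compound 2 to compound 3 (0.64 log units; beyond the scatter) shows the benzyl amide reading beyond the scatter above the 2-chlorophenyl one, and an at least 4.4-fold lower number from compound 1 to compound 2 (0.64 log units; beyond the scatter) shows the 2-chlorophenyl amide below the 3-methylphenyl one. A return to a directly attached chlorophenyl is therefore expected to lower the number, an at least 2.2-fold lower number from compound 3 to compound 4 (0.34 log units; beyond the scatter). Compound 4 is estimated at 45000 nM, within 12000 nM to 150000 nM.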

Compound 4, half-maximal inhibitory concentration: > 100000 nM
Compound 4 was reported as a limit; the forecaster's own chance of this, stated with the estimate: 40%; middle value at least 2.2-fold (0.34 log units) away from the limit.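

Having a chlorine on the phenyl ring is not enough to give a number at the amide-type nitrogen: in this assay, 4-chlorophenyl in place of 2-chlorophenyl gives an at least 4.4-fold higher number from compound 2 to compound 4 (0.64 log units; beyond the scatter). The steps from compound 1 to compound 4 and from compound 3 to compound 4 cannot be read, as both ends of each are limits. Compound 2 remains the only one of the four with a number: the limit of > 100000 nM in this assay, at which 3 of the 4 values shown sit.

On these data alone, whether a dichlorophenyl group or a longer alkyl chain on the amide-type nitrogen would give a number stays open. As far as these compounds go, how far compound 1, compound 3 and compound 4 lie past the limit also stays open.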